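The source may hold more compounds than are shown below. What is called first, only, known or untested is meant among the compounds shown, and "the series" means these compounds.

In an in vitro functional assay on cells for agonist activity at Bombesin receptor subtype-3 (Mus musculus), read by luminescence and calcium flux (a higher number here means that more compound is needed for the effect, a lower number that less compound is needed), the measured compounds are:

- compound 1, `Cc1cccc(Cc2cnc(CCc3ccc(-c4ccccc4C(=O)O)cc3)[nH]2)c1`, gives 75 nM
- compound 2, `CC(C)(C)Cc1cnc(CCc2ccc(-c3ccccc3C(=O)O)cc2)[nH]1`, gives 6.3 nM

Within the data shown here, compound 2 gives the lowest of the two numbers; its nearest neighbour is compound 1, and the only step known, a 12-fold lower number from compound 1 to compound 2 (1.08 log units; beyond the scatter), is large. That step swapped an aromatic group for a branched saturated one on the chain carbon at this position, and it lowered the number a great deal.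

Compound 3, `O=C(O)c1ccccc1-c1ccc(CCc2ncc(-c3ccccc3)[nH]2)cc1`, takes the other direction: phenyl in place of neopentyl on an aromatic carbon. Here the aromatic ring sits directly on the ring carbon, with no chain carbon in between, so no measured step copies this change exactly. Among the measured compounds shown here, what the data do show is that, at this part of the shared core, the one aromatic group seen so far gave a clearly higher number than the neopentyl group. Compound 3 is therefore expected to show a 4.8-fold higher number from compound 2 to compound 3 (0.68 log units; beyond the scatter), a rise that is estimated to be smaller than that earlier step because a 12-fold lower number from compound 1 to compound 2 (1.08 log units; beyond the scatter) also included the loss of the chain carbon and a methyl on the ring, which compound 3 does not share in the same way. For compound 3 in this assay the estimate is 30 nM, with a range from 8 nM to 120 nM.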

Compound 3, half-maximal effective concentration: 872 nM
Compound 3: the middle estimate sits 29-fold (1.46 log units) below what was measured; the measured number lies above the stated range.
By their numbers in this assay, from the lowest: compound 2; then compound 1; then compound 3.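

In this assay, among these compounds, phenyl in place of neopentyl on this aromatic carbon gives a 140-fold higher number from compound 2 to compound 3 (2.14 log units; beyond the scatter) and is the largest change seen so far, so what sits at this place can shift the number far more than the first pair of compounds showed. The same phenyl set against 3-methylbenzyl gives a 12-fold higher number from compound 1 to compound 3 (1.07 log units; beyond the scatter) and shows that the two compounds with an aromatic ring here do not read alike: having such a ring is not all that matters, and how it is attached or decorated counts as well. That step removes the chain carbon and the methyl together, and these compounds cannot tell which of the two accounts for the rise.

Nothing measured here gives a reason for these shifts. Open too, from the compounds shown here alone, is where plain benzyl and cyclohexyl would fall at this place: benzyl, without the methyl, would separate the effect of the chain carbon from that of the methyl, and cyclohexyl, sitting directly on the aromatic carbon, would show whether a saturated ring behaves like phenyl or like neopentyl.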